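The compounds below may be only part of what the source reports. "The series", "measured", "known", "first", "only" and "open" are said of these compounds alone.

Measured so far in a functional assay on MCF7 cells (Homo sapiens) for cytotoxicity, read by MTT assay, with a stated time of 72 h; on this read-out lower numbers stand for stronger inhibition and higher numbers for weaker inhibition:
- compound 1 `COc1ccc(/C=C2\CCC/C(=C\c3cccc(Br)c3)C2=O)cc1OC` gives 5300 nM
- compound 2 `COc1cccc(/C=C2\CCC/C(=C\c3ccc(OC)c(OC)c3)C2=O)c1` gives 4600 nM

Compound 2, at 4600 nM, has the lower of these two numbers, but its gap to compound 1 lies within the scatter, so the pair cannot be ranked. The next compound to be tested is compound 3 `COc1cc(/C=C2\CCC/C(=C\c3ccc(OC)c(OC)c3)C2=O)cc(OC)c1`. It keeps the shared core and changes one thing: methoxy in place of hydrogen on an aromatic carbon.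

Among the compounds with values here, only one measured step bears on this change, and only indirectly. It is a 1.2-fold lower number from compound 1 to compound 2 (0.06 log units; within the scatter), which exchanges bromo for methoxy on an aromatic carbon. That step is small, but it swaps one group for another and does not add a group where a hydrogen stood. Within the data shown here, no measured pair shows what adding a methoxy does here, so the expectation is weak and the range must stay wide. No change beyond the scatter is expected in this assay, in either direction. The expected step is a 1.1-fold lower number from compound 2 to compound 3 (0.03 log units; within the scatter). For compound 3 the estimate is 4300 nM, with an expected range from 1700 nM to 11000 nM.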

Compound 3, half-maximal inhibitory concentration: 3900 nM
Estimate against measurement, compound 3: 1.1-fold (0.04 log units) above, and the stated range covers the measured number.
By their numbers in this assay, from the lowest: compounds 3, 2 and 1 (each within the scatter of the next).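

Putting methoxy in place of hydrogen on this aromatic carbon, meta to a large group and meta to a methoxy group, gives a 1.2-fold lower number from compound 2 to compound 3 (0.07 log units; within the scatter) in this assay and so produces no change that can be told apart from ordinary variation between repeated measurements. Within the data shown here, this is the first measured pair here in which a group is added where a hydrogen stood, and it shows that compound 3 can carry the extra methoxy, with its 2 heavy atoms, at this position without a detectable shift in this read-out. No supporting measurement is available to explain this lack of change, so it remains a plain observation.

Going by these compounds, what happens with a different kind of group at this position remains open: an amine, a carboxylic acid or a longer chain could move the number in either direction or leave it where it is. On these data alone, it is also open whether compound 2 and compound 3 would remain indistinguishable in another cell line or after a different exposure time.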